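The source may hold more compounds than are shown below. What is called first, only, known or untested is meant among the compounds shown, and "the series" means these compounds.

Compound 1 `COc1ccc(/C=C/C(=O)c2c(C)[n+]([O-])c3ccccc3[n+]2[O-])cc1` and compound 2 `Cc1ccc(/C=C/C(=O)c2c(C)[n+]([O-])c3ccccc3[n+]2[O-])cc1` share one core and differ only in the group on an aromatic carbon of the pendant ring. In a functional assay on CCRF-CEM cells (Homo sapiens) for inhibition, with a stated time of 3 days (a lower number here means a stronger inhibitor, a higher number a weaker inhibitor), compound 1 gives 27600 nM, and compound 2 gives 22400 nM. Within the data shown here, the one step measured so far, a 1.2-fold lower number from compound 1 to compound 2 (0.09 log units; within the scatter), shows that swapping one small group for another at this position left the read-out essentially unchanged. Compound 2 thus has the lowest of the two numbers recorded in this assay, though the gap to compound 1 is within the scatter, so no order between them can be claimed.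

Compound 3 `Cc1c(C(=O)/C=C/c2ccc(F)cc2)[n+]([O-])c2ccccc2[n+]1[O-]` carries the next change at the same position: fluoro in place of methyl on an aromatic carbon. Among the measured compounds shown here, the only step that bears on it is the one from compound 1 to compound 2, which was small; a further single-atom swap at this aromatic carbon is therefore expected to give a step of similar size, a 1.1-fold higher number from compound 2 to compound 3 (0.05 log units; within the scatter), with no clear direction beyond the scatter. Compound 3 is accordingly estimated at 25000 nM in this assay, with a range from 10000 nM to 60000 nM.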

Compound 3, half-maximal inhibitory concentration: 10000 nM
Estimate against measurement, compound 3: 2.5-fold (0.40 log units) above; low and high end bracket the measured number.
By their numbers in this assay, from the lowest: compound 3; then compounds 2 and 1 (each within the scatter of the next).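

In this assay the position proves less indifferent than the first pair suggested: fluoro in place of methyl gives a 2.2-fold lower number from compound 2 to compound 3 (0.35 log units; beyond the scatter) and fluoro in place of methoxy gives a 2.8-fold lower number from compound 1 to compound 3 (0.44 log units; beyond the scatter), so both steps are modest but clear the scatter. Methyl and methoxy could not be told apart, whereas fluoro stands apart from both, which makes compound 3 the strongest inhibitor of the three and shows that the choice of group on this aromatic carbon, para to a large group, can move the read-out. No measurement at hand explains why this one change separates itself from the other two groups.

The compounds shown leave open whether the gain belongs to fluoro alone or extends to other halogens such as chloro or bromo, and how an amine, a carboxylic acid or a longer alkyl chain would fare on the same carbon. They also leave open whether fluoro would give a step of like size at another carbon of the pendant ring, or whether a change to the shared core would alter the picture.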